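The source may hold more compounds than are shown below. What is called first, only, known or untested is meant among the compounds shown, and "the series" means these compounds.

Compound 1 `Cc1c(O)nc(S(=O)(=O)Cc2ccc(Br)cc2)nc1Cc1c(Cl)cccc1Cl` in a functional assay on MT4 cells (Homo sapiens) for cytotoxicity, read by MTT assay (on this read-out lower numbers stand for higher toxicity in this test and higher numbers for lower toxicity in this test), gives > 50000 nM, a limit.
Compound 2 `COc1ccc(CCSc2nc(Cc3c(Cl)cccc3Cl)c(C)c(=O)[nH]2)cc1` in this assay gives > 57000 nM, also a limit.
Compound 3 `Cc1c(O)nc(SCc2ccc(Br)cc2)nc1Cc1c(Cl)cccc1Cl` in this assay gives 13000 nM.

Compound 2 thus stands at a limit of this assay, not at a measured number, so its toxicity is only known to be weak; the same holds for compound 1 at its own limit (the limit of > 50000 nM in this assay, at which 1 of the 3 values shown sits), while compound 3 alone gives a number. Compound 4 `COc1ccc(CSc2nc(Cc3c(Cl)cccc3Cl)c(C)c(=O)[nH]2)cc1` is not yet measured. It arises from compound 2 by a single change: 4-methoxyphenyl in place of 4-methoxybenzyl on a saturated chain carbon bound to a sulfur. The chain between the sulfur and the aromatic ring becomes one carbon shorter, so the ring sits one carbon from the sulfur, as it does in compound 3 and compound 1. Within the data shown here, no measured pair in this set differs in only one place, so the size of the step can only be guessed. Because compound 3 gives 13000 nM with such a shorter link, a modest move toward stronger toxicity is expected, though it may stay within the scatter. The step from compound 2 to compound 4 is expected to be an at least 1.9-fold lower number from compound 2 to compound 4 (0.27 log units; that floor lies within the scatter). Compound 4 is therefore expected to give about 30000 nM, within 10000 nM to 70000 nM.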

Compound 4, half-maximal cytotoxic concentration: 32000 nM
The estimate for compound 4 lay 1.1-fold (0.03 log units) below the measured number; the range from low to high includes it.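

Among these compounds, the change from 4-methoxybenzyl to 4-methoxyphenyl on a saturated chain carbon bound to a sulfur gives the first step in this assay between compounds that differ in one place: an at least 1.7-fold lower number from compound 2 to compound 4 (0.25 log units; that floor lies within the scatter). The shorter link thus yields a measured number, but this floor alone does not show a real change in toxicity, and the true step could be larger. Only a lower bound can be given because compound 2 stands at a limit: the limit of > 57000 nM in this assay, at which 1 of the 4 values shown sits.

From the compounds shown here alone, what a longer chain on the sulfur would give remains open, since the comparison covers only the two chain lengths in compound 2 and compound 4. Also open, going by these compounds, is whether an amine in place of the methoxy group on the ring of compound 4 would move the number at all.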